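Benzyl for phenyl on the ring nitrogen: working notes

The source may hold more compounds than are shown below. What is called first, only, known or untested is meant among the compounds shown, and "the series" means these compounds.

Measured so far in a functional assay on the whole organism (strain Swiss albino) for inhibition, with Mus musculus as the target, in the maximal electroshock model, with a stated time of 2 h, at a dose of 25 mg/kg by the intraperitoneal route; a higher number here means more inhibition at the dose given (going by the name of the read-out), a lower number less inhibition:
Compound 1, `O=C1C(c2ccccc2)CC(c2ccccc2)C(=O)N1c1ccccc1`, gives 38.3%.
Compound 2, `O=C1C(c2ccccc2)CC(c2ccccc2)C(=O)N1Cc1ccccc1`, gives 64.5%.
Compound 3, `O=C1C(c2ccccc2Cl)CC(c2ccccc2Cl)C(=O)N1c1ccccc1`, gives 40.6%.

One change has been made between measured compounds: benzyl in place of phenyl on an amide-type nitrogen in a ring. That step is a number 26.2 percentage points higher from compound 1 to compound 2 (beyond the scatter). Compound 3 and compound 1 differ in their cores, and that difference is not broken down here; their two values lie within the scatter of each other.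

Compound 4, `O=C1C(c2ccccc2Cl)CC(c2ccccc2Cl)C(=O)N1Cc1ccccc1`, is not yet measured. It relates to compound 3 as compound 2 relates to compound 1: benzyl in place of phenyl on an amide-type nitrogen in a ring. The places are not the same word for word, since the ring atoms bear a 2-chlorophenyl group in compound 3 and a phenyl group in compound 1, so this is the same kind of change, not the same change. The step from compound 3 to compound 4 is expected to be a number 22.4 percentage points higher from compound 3 to compound 4 (beyond the scatter), resting on a number 26.2 percentage points higher from compound 1 to compound 2 (beyond the scatter) in this assay. Compound 4 is therefore estimated at 63%, expected between 48% and 78%.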

Compound 4, a percentage reported as inhibition, in the whole organism at one dose (the size of the read-out at that dose, not a potency): 58.2%
The estimate for compound 4 lay 4.8 percentage points above the measured number; measured number inside the range.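

In this assay, benzyl in place of phenyl on the amide-type nitrogen in the ring also gives a number 17.6 percentage points higher from compound 3 to compound 4 (beyond the scatter), so the change keeps its direction on the core bearing 2-chlorophenyl groups. The two steps can be read as one effect of similar size: the same change on two cores in this assay, a number 26.2 percentage points higher (beyond the scatter) from compound 1 to compound 2 and a number 17.6 percentage points higher (beyond the scatter) from compound 3 to compound 4, 8.6 percentage points apart, within the scatter of two such steps. Going by these compounds alone, this rests on only two pairs and two cores at a single dose, so it shows neither a rule for other cores nor any change in potency.

Still open, as far as these compounds go, is whether the step holds with a longer chain on that nitrogen, such as phenylethyl, or with a chain ending in an amine. Also open, from the compounds shown here alone, is how a methoxy group on the benzyl ring would affect it.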